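Swapping Methoxy for Chloro on an Amide Substituent

The compounds below may be only part of what the source reports. "The series", "measured", "known", "first", "only" and "open" are said of these compounds alone.

Compound 2 `COc1ccc(NC(=O)c2c(O)c3cccnc3n(-c3ccccc3)c2=O)cn1` and compound 1 `CNC(=O)c1c(O)c2cccnc2n(-c2ccccc2)c1=O` share a core and differ only in the group carried on the amide nitrogen. In a functional assay on the whole organism for inhibition, with Rattus norvegicus as the target, read by paw edema, at a dose of 100 mg/kg by the oral route (a higher number here means more inhibition at the dose given (going by the name of the read-out), a lower number less inhibition), compound 1 gives 9.6%, and compound 2 gives 13.1%. Of these two numbers, compound 2 holds the higher one, yet the step of a number 3.5 percentage points higher from compound 1 to compound 2 (within the scatter) lies within the usual scatter, so the two compounds cannot be told apart on this read-out. Compound 3 `O=C(Nc1ccc(Cl)nc1)c1c(O)c2cccnc2n(-c2ccccc2)c1=O` keeps everything in compound 2 and differs by chloro in place of methoxy on an aromatic carbon. Going by the values given here, no measured step shows what this exchange does; the only step available, from compound 1 to compound 2, altered a different part of the molecule and stayed within the scatter. On that basis the expected step of a number 0.1 percentage points lower from compound 2 to compound 3 (within the scatter) is none beyond the scatter. Compound 3 is therefore estimated at 13% in this assay, with a range from 2% to 26%.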

Compound 3, a percentage reported as inhibition, in the whole organism at one dose (the size of the read-out at that dose, not a potency): 9.2%
For compound 3 the middle estimate is 3.8 percentage points above the measured one, and the stated range covers the measured number.
By their numbers in this assay, from the lowest: compounds 3, 1 and 2 (each within the scatter of the next).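

The exchange of methoxy for chloro on this aromatic carbon now has a direct reading in this assay, namely a number 3.9 percentage points lower from compound 2 to compound 3 (within the scatter), so on this read-out the swap cannot be told apart from no change at all. The comparison with the small methyl group on the amide nitrogen ends the same way, with a number 0.4 percentage points lower from compound 1 to compound 3 (within the scatter), so neither 6-methoxypyridin-3-yl nor 6-chloropyridin-3-yl separates from methyl. No supporting measurement is available to explain these readings.

On these data alone, what an amine or a carboxylic acid on this same ring carbon would do remains open. Also open, as far as these compounds go, is whether any group on the amide nitrogen can move the number beyond the scatter, and a single dose says nothing about potency.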